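From ethyl to propyl: expected unbound share

A few compounds are considered here, and "the series" means these few. Any claim that something is new, unique, unknown or untested is made for them only; others in the source may bear on it.

Measured in an ADME assay on a cell-free system (plasma, Mus musculus) for protein binding, using equilibrium dialysis, with a stated time of 5 h, tested at 10 uM; a higher number here means a larger unbound share of the compound, a lower number a smaller unbound share:
compound 1 `CC[C@@H](c1ccc(C(=O)O)c(Oc2cccc(Cl)c2)c1F)N1CCC[C@H](n2cc(C)c(=O)[nH]c2=O)C1` gives "not determined" (no result reported)
compound 2 `Cc1cn([C@H]2CCCN([C@H](CC(C)C)c3ccc(C(=O)O)c(Oc4cccc(Cl)c4)c3F)C2)c(=O)[nH]c1=O` gives < 0.01
compound 3 `CC[C@H](c1ccc(C(=O)O)c(Oc2cccc(Cl)c2)c1F)N1CCC[C@H](n2cc(C)c(=O)[nH]c2=O)C1` gives "not determined" (no result reported)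

Compound 1 has no number to start from, since it stands at "not determined" (no result reported). Compound 3 also stands at "not determined" (no result reported), so nothing can be said about (the fact that compounds 1 and 3 differ only in the configuration as drawn). Among the measured compounds shown here, the only result comes from compound 2 , whose < 0.01 is a limit of the assay and not a number.

Compound 4 `CCC[C@@H](c1ccc(C(=O)O)c(Oc2cccc(Cl)c2)c1F)N1CCC[C@H](n2cc(C)c(=O)[nH]c2=O)C1` has yet to be measured. The structural change is methyl in place of hydrogen on a saturated chain carbon, three bonds along the chain from an amine nitrogen in a ring and an aromatic carbon, which reads as ethyl to propyl. For the measured compounds named here, with no measured step to draw on, no step beyond the usual scatter is expected from this change in this assay, in either direction. The expectation leans on compound 2 and its < 0.01, and a very small unbound share seems likely, quite possibly reported only as a limit.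

For compound 4 the unbound fraction is estimated at 0.008, with an expected range of 0.003 to 0.02.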

Compound 4, unbound fraction: 0.007
Beside the measured number, compound 4's estimate is 1.1-fold (0.06 log units) above it; low and high end bracket the measured number.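

In this assay, among the compounds shown here, compound 1 gives "not determined" (no result reported), and no step from it to compound 4 can be read. The compounds shown leave open whether ethyl to propyl shifts the unbound fraction at all, and whether the configuration as drawn matters for it.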